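Swapping Chloro for Fluoro in a Second Pair

The compounds below may be only part of what the source reports. "The series", "measured", "known", "first", "only" and "open" are said of these compounds alone.

Compound 1, `COc1ccc(C2N=C(SCc3ccc(Cl)cc3)NC(C)=C2C(=O)Nc2ccc(Br)cc2)cc1`, gives 39.2% in a functional assay on the whole organism (artery, strain albino) with Rattus norvegicus as the target, with a stated time of 360 min, at a dose of 10 mg/kg by the oral route; on this read-out higher numbers stand for more inhibition at the one dose given (going by the name of the read-out) and lower numbers for less inhibition.
Compound 2, `COc1ccc(C2N=C(SCc3ccc(F)cc3)NC(C)=C2C(=O)Nc2ccc(Br)cc2)cc1`, gives 33.5% in this assay.
Compound 3, `CC1=C(C(=O)Nc2ccc([N+](=O)[O-])cc2)C(c2ccc(Br)cc2)N=C(SCc2ccc(Cl)cc2)N1`, gives 39.2% in this assay.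

Compound 1 and compound 2 differ in a single place: fluoro in place of chloro on an aromatic carbon. This change gave a step of a number 5.7 percentage points lower from compound 1 to compound 2 (within the scatter), so the two values cannot be told apart by this assay.

Compound 3 carries a different core from compound 1, and the difference between the two cores is not broken down here. At the digits given, compound 3 and compound 1 read the same in this assay, and compound 2 sits within the scatter of both.

Compound 4, `CC1=C(C(=O)Nc2ccc([N+](=O)[O-])cc2)C(c2ccc(Br)cc2)N=C(SCc2ccc(F)cc2)N1`, is to compound 3 what compound 2 is to compound 1: fluoro in place of chloro on an aromatic carbon. Both changes sit at the same kind of place, described in the same words, so this is the same change made on another core.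

Because the earlier change gave a number 5.7 percentage points lower from compound 1 to compound 2 (within the scatter), the step from compound 3 to compound 4 is expected to be about as small, at a number 5.2 percentage points lower from compound 3 to compound 4 (within the scatter). Compound 4 is therefore estimated to give 34% in this assay, most likely between 22% and 46%.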

Compound 4, a percentage reported as inhibition, in the whole organism at one dose (the size of the read-out at that dose, not a potency): 38.7%
Compound 4: the middle estimate sits 4.7 percentage points below what was measured; low and high end bracket the measured number.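

In this assay, fluoro in place of chloro on the second core gave a number 0.5 percentage points lower from compound 3 to compound 4 (within the scatter) and so left the two compounds indistinguishable, just as on the first core. Set side by side, the two steps do not differ: the same change on two cores in this assay, a number 5.7 percentage points lower (within the scatter) from compound 1 to compound 2 and a number 0.5 percentage points lower (within the scatter) from compound 3 to compound 4, 5.2 percentage points apart, within the scatter of two such steps. For the compounds shown here, this shows that on these two cores the swap from 4-chlorobenzyl to 4-fluorobenzyl produced no step that this read-out can resolve, but it does not show that the two groups are truly equivalent, that a small real effect is absent, or that the same would hold on a third core.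

The compounds shown leave open whether anything placed on that same aromatic carbon could move the read-out beyond the scatter, for example an amine, a nitrile, a carboxylic acid or simply hydrogen. They also leave open whether the pairs would still read alike at a different dose or time, since each comparison here rests on a single dose and a single time.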